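From Fluoro to Isobutylcarbamoyl on a Fused Ring

The source may report more compounds than this note shows. Statements on the series, on what has been measured and on what is new or still open speak of the compounds shown alone.

Two compounds have been measured in an assay for inhibition of serine/threonine-protein kinase PLK2 (Homo sapiens), read by FRET and Z'-LYTE, with a stated time of 1 h; a lower number here means a stronger inhibitor, a higher number a weaker inhibitor:

Compound 1 `CCCNS(=O)(=O)c1ccc(Nc2ncc3c(n2)N(C2CCCC2)[C@H](CC)C(=O)N3C)cc1`: 17.8 nM
Compound 2 `CC[C@@H]1C(=O)N(C)c2cnc(-n3ccc4cc(F)ccc43)nc2N1C1CCCC1`: 969 nM

Compound 2 stands at the higher of the two numbers, that is, it is the weaker inhibitor of the pair. Among the measured compounds shown here, its only neighbour is compound 1, whose number is far lower, and the gap between them lies well beyond the usual scatter of repeated measurements. The two compounds share a core but differ in more than one place, so nothing can be drawn from them about a single change.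

Compound 3 `CC[C@@H]1C(=O)N(C)c2cnc(-n3ccc4cc(C(=O)NCC(C)C)ccc43)nc2N1C1CCCC1` keeps the core and the fused ring system of compound 2 and differs from it in one place: isobutylcarbamoyl in place of fluoro on an aromatic carbon. For the measured compounds named here, no measured pair shows this same change, so the size of its effect is uncertain. The group that enters brings a hydrogen-bond donor and acceptor where none stood before, and such a change is expected to move the number somewhat, most likely toward a lower value, though a step within the scatter cannot be ruled out. Compound 3 is estimated to give about 500 nM in this assay, within a range from 100 nM to 3000 nM. This expected result would mean an estimated step of a 1.9-fold lower number from compound 2 to compound 3 (0.29 log units; within the scatter).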

Compound 3, half-maximal inhibitory concentration: 18.6 nM
Beside the measured number, compound 3's estimate is 27-fold (1.43 log units) above it, outside the stated range (below it).
By their numbers in this assay, from the lowest: compounds 1 and 3 (each within the scatter of the next); then compound 2.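

In this assay, putting isobutylcarbamoyl in place of fluoro on this aromatic carbon gives a 52-fold lower number from compound 2 to compound 3 (1.72 log units; beyond the scatter), and this is the first change in a single place that can be read among these compounds. It shows that the group at this position of the six-membered carbon ring strongly affects the number, and that the weak result of compound 2 cannot be held against the fused ring system as a whole, since compound 3 keeps that ring system and the shared core. No measurement shown here explains the step, and the step alone cannot say whether the carbonyl, the amide hydrogen or the isobutyl chain accounts for it.

As far as these compounds go, what remains open is which part of the new group carries the gain: a plain carboxamide, a methylcarbamoyl group or a longer chain on the amide nitrogen would begin to separate these parts. From the compounds shown here alone, it is also open whether a carboxylic acid or an amine at this same carbon would move the number in the same direction, or whether the gain is particular to an amide.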